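Moving the thiophene attachment: compound 2 to compound 3

The source may report more compounds than this note shows. Statements on the series, on what has been measured and on what is new or still open speak of the compounds shown alone.

Measured so far in a functional assay on cells (Cancer cell lines, Homo sapiens) for inhibition; on this read-out lower numbers stand for stronger inhibition of growth and higher numbers for weaker inhibition of growth (two compounds):
- compound 1 (`N=C(N)N/N=C/c1c(-c2ccsc2)nc2sccn12`) gives 17400 nM
- compound 2 (`N=C(N)N/N=C/c1c(-c2ccsc2)nc2n1CCS2`) gives 32400 nM

Compound 2 at 32400 nM and compound 1 at 17400 nM lie within the scatter of each other, so the two cannot be separated in this assay on this evidence.

Compound 3 (`N=C(N)N/N=C/c1c(-c2cccs2)nc2n1CCS2`) has not yet been measured. It differs from compound 2 by thiophen-2-yl in place of thiophen-3-yl on an aromatic carbon, the two having the same atoms joined differently. For the measured compounds named here, no measured pair shows this change on its own, so the data give no direct size for it. Only a small step inside the scatter is expected in this assay here, with neither direction favoured. The estimated change is a 1.1-fold lower number from compound 2 to compound 3 (0.03 log units; within the scatter) and nothing larger is claimed. The estimate rests on compound 2 at 32400 nM as its starting point. The expected value for compound 3 is 30000 nM with an estimated range from 13000 nM to 70000 nM in this read-out.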

Compound 3, concentration for 50% growth inhibition: 17400 nM
For compound 3 the middle estimate is 1.7-fold (0.24 log units) above the measured one, and the stated range covers the measured number.
By their numbers in this assay, from the lowest: compounds 1, 3 and 2 (each within the scatter of the next).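

In this assay, for the compounds shown here, thiophen-2-yl in place of thiophen-3-yl gives a 1.9-fold lower number from compound 2 to compound 3 (0.27 log units; within the scatter), the first direct reading of any change on this aromatic carbon. On this single pair, the two thiophene isomers cannot be separated, so the read-out gives no sign that the change between these two groups matters at this position on the core of compound 2. Nothing measured on these compounds bears on this step beyond the growth-inhibition numbers themselves, so the result stands without an explanation.

Going by these compounds alone, whether the same swap would also stay inside the scatter on the core of compound 1 remains open, as the only reading of this change comes from the core of compound 2. The pair also says nothing about how far this position can depart from a thiophene, and a phenyl ring, a pyridine ring or a simple methyl group on the same aromatic carbon would show whether the flat response seen here extends beyond the two isomers.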